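The source may hold more compounds than are shown below. What is called first, only, known or untested is meant among the compounds shown, and "the series" means these compounds.

Compound 1 `CC(C)n1ncc2c(C(=O)NCc3cn(-c4cccc(Br)c4)nn3)cccc21` is inactive up to the assay limit: in a functional assay on MCF7 cells (Homo sapiens) for inhibition, read by MTT assay, with a stated time of 72 h (a lower number here means a stronger inhibitor, a higher number a weaker inhibitor), compound 1 gives > 40000 nM, a limit rather than a number. Compound 2 `CCc1ccc(-n2cc(CNC(=O)c3cccc4c3cnn4C(C)C)nn2)cc1` likewise reaches only the limit, giving > 40000 nM in this assay.

The step that the two limits leave unreadable from compound 1 to compound 2 is therefore unreadable, as both values sit at the limit of > 40000 nM in this assay, at which 2 of the 2 values shown sit. Compound 3 `CC(C)n1ncc2c(C(=O)NCc3cn(Cc4ccccc4)nn3)cccc21` differs from compound 2 by benzyl in place of 4-ethylphenyl on an aromatic nitrogen. Among the measured compounds shown here, no measured step shows a readable size, so no shift beyond the scatter can be predicted in either direction. Compound 3 is expected to give about 60000 nM (estimated range 20000 nM to 200000 nM), an estimated step that the limit leaves unreadable from compound 2 to compound 3, most likely again only a limit.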

Compound 3, half-maximal inhibitory concentration: 9170 nM
The estimate for compound 3 lay 6.5-fold (0.82 log units) above the measured number; the measured number lies below the stated range.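

On this aromatic nitrogen, the group matters: benzyl in place of 4-ethylphenyl gives an at least 4.3-fold lower number from compound 2 to compound 3 (0.63 log units; beyond the scatter) in this assay, and benzyl in place of 3-bromophenyl gives an at least 4.3-fold lower number from compound 1 to compound 3 (0.63 log units; beyond the scatter). Among the compounds shown here, compound 3 thus gives the first readable value of the three, with the same core and only this group changed. Both sizes are minimums, since the other two compounds reach only a limit: the limit of > 40000 nM in this assay, at which 2 of the 3 values shown sit.

The compounds shown leave open whether a longer chain, such as phenylethyl, would lower the number further. From the compounds shown here alone, how a methoxy group on the benzyl ring would shift it also remains open.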